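Hexyloxy for Cyclopropylamino on a Cytotoxicity-Silent Core

The source may report more compounds than this note shows. Statements on the series, on what has been measured and on what is new or still open speak of the compounds shown alone.

This account follows the change from compound 2, `Nc1nc(NC2CC2)c2ncn(/C=C3/CC3(CO)CO)c2n1`, to compound 4, `CCCCCCOc1nc(N)nc2c1ncn2/C=C1/CC1(CO)CO`. In an ADME assay on HFF cells (Homo sapiens) for cytotoxicity, with a stated time of 8 days (on this read-out higher numbers stand for lower toxicity in this test and lower numbers for higher toxicity in this test), compound 2 gives only a limit of the assay, > 300000 nM. Compound 1, `CCCSc1nc(N)nc2c1ncn2/C=C1/CC1(CO)CO`, likewise reaches only a limit in this assay, > 300000 nM. Compound 3, `Nc1nc2c(ncn2/C=C2/CC2(CO)CO)c(=O)[nH]1`, also returns a limit in this assay, > 300000 nM. All three measured compounds therefore sit at the same point, described by the limit of > 300000 nM in this assay, at which 3 of the 3 values shown sit, and compound 2 stands there with no number of its own. The change to compound 4 is hexyloxy in place of cyclopropylamino on an aromatic carbon. Within the data shown here, the only measured step in one place is a step that the two limits leave unreadable from compound 1 to compound 2, which the two limits leave unreadable, so no measured step gives a size to expect. From the shared behaviour in this assay the step from compound 2 to compound 4 is expected to be a number no higher from compound 2 to compound 4 (the limit leaves the size open), that is, none beyond the scatter. Compound 4 is estimated at 300000 nM, with the range from 100000 nM to 1000000 nM, most likely again as a limit.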

Compound 4, half-maximal cytotoxic concentration: > 200000 nM
Compound 4 ended at the assay's limit; the forecaster's own chance of this, stated with the estimate: 85%; the middle value lies beyond the limit too.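

Among these compounds, compound 1, compound 2 and compound 4 all return only limits in this assay, so no step between them can be read. The compounds shown leave open whether any group on this aromatic carbon gives a cytotoxic concentration that can be measured as a number.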